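A sulfonyl swap repeated on a second core

The source may hold more compounds than are shown below. What is called first, only, known or untested is meant among the compounds shown, and "the series" means these compounds.

Measured compounds:
Compound 1 `N#C/C(=C\c1ccccc1OS(=O)(=O)c1ccccc1[N+](=O)[O-])C(=O)Nc1nnc(Cc2cccc3ccccc23)s1`: in a functional assay on RS4-11 cells (Homo sapiens) for inhibition, read by CCK-8 assay, with a stated time of 48 h, tested at 20 uM (on this read-out higher numbers stand for more inhibition of growth at the one concentration tested and lower numbers for less inhibition of growth), compound 1 gives 66%.
Compound 2 `N#C/C(=C\c1ccccc1OS(=O)(=O)c1ccc(Cl)cc1)C(=O)Nc1nnc(Cc2cccc3ccccc23)s1`: in this assay compound 2 gives 68%.
Compound 3 `N#C/C(=C\c1ccccc1OS(=O)(=O)c1ccccc1[N+](=O)[O-])C(=O)Nc1nnc(Cc2ccccc2)s1`: in this assay compound 3 gives 71%.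

The change on the sulfonyl sulfur has been made once before, from compound 1 to compound 2: 4-chlorophenyl in place of 2-nitrophenyl on a sulfonyl sulfur. Its step was a number 2 percentage points higher from compound 1 to compound 2 (within the scatter). Compound 4 `N#C/C(=C\c1ccccc1OS(=O)(=O)c1ccc(Cl)cc1)C(=O)Nc1nnc(Cc2ccccc2)s1` carries the same change on the core of compound 3: 4-chlorophenyl in place of 2-nitrophenyl on a sulfonyl sulfur. The two place descriptions agree word for word, so this is the same change, only on a different core. The cores differ as follows: phenyl in place of naphthalen-1-yl on a saturated chain carbon bound to an aromatic carbon, with the step of a number 5 percentage points higher from compound 1 to compound 3 (within the scatter).

For compound 4 a step of a number 2 percentage points higher from compound 3 to compound 4 (within the scatter) is expected, beside the earlier step, because a number 2 percentage points higher from compound 1 to compound 2 (within the scatter) stayed within the scatter. Compound 4 is therefore estimated at 73%, between 61% and 84%.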

Compound 4, percent growth inhibition at one concentration: 73%
The estimate for compound 4 equals the measured number at the digits printed; measured number inside the range.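

In this assay, putting 4-chlorophenyl in place of 2-nitrophenyl on the sulfonyl sulfur gives a step of a number 2 percentage points higher from compound 3 to compound 4 (within the scatter), and this agrees with the earlier step on the other core: the same change on two cores in this assay, a number 2 percentage points higher (within the scatter) from compound 1 to compound 2 and a number 2 percentage points higher (within the scatter) from compound 3 to compound 4, 0 percentage points apart, within the scatter of two such steps

Putting phenyl in place of naphthalen-1-yl gives a step of a number 5 percentage points higher from compound 2 to compound 4 (within the scatter), and this too repeats: the same change on two cores in this assay, a number 5 percentage points higher (within the scatter) from compound 1 to compound 3 and a number 5 percentage points higher (within the scatter) from compound 2 to compound 4, 0 percentage points apart, within the scatter of two such steps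

So the two changes carry from one core to the other without a visible gap, but all these steps lie within the scatter, so this shows only that neither change moved the read-out measurably, not that a real effect of either change was carried across.

The compounds shown leave open whether other groups on the sulfonyl sulfur, such as a methyl or a 4-aminophenyl, would also carry across. They also leave open whether a real, larger step would repeat on both cores.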